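Diethylsulfamoyl in place of oxazolyl: expected cytotoxicity

The source may hold more compounds than are shown below. What is called first, only, known or untested is meant among the compounds shown, and "the series" means these compounds.

Compound 2 `O=C(Nc1ccc(Cl)cc1)C1CCCN(C(=O)c2cccc(-c3cnco3)c2)C1` stands lowest of the two numbers in an ADME assay on PC-3 cells (Homo sapiens) for cytotoxicity, read by WST assay, tested at 100 uM (a lower number here means less inhibition, a higher number more inhibition at the concentration tested (going by the name of the read-out)), at 0%. Compound 1 `O=C(Nc1ccc(Cl)cc1)C1CCCN(C(=O)c2cccc(-c3nccs3)c2)C1` gives 32%, and the step of a number 32 percentage points lower from compound 1 to compound 2 (beyond the scatter) shows that exchanging the aryl substituent moves the read-out well beyond the scatter. Compound 3 `CCN(CC)S(=O)(=O)c1cccc(C(=O)N2CCCC(C(=O)Nc3ccc(Cl)cc3)C2)c1` carries diethylsulfamoyl in place of 1,3-oxazol-5-yl on an aromatic carbon. Going by the values given here, no measured step covers a diethylsulfamoyl group; only the one step above bears on the change, and it shows the read-out responds strongly to this substituent. Compound 2 at 0% leaves no room for a fall. The estimated step is a number 15 percentage points higher from compound 2 to compound 3 (beyond the scatter), upward but uncertain. For compound 3 the expected value is 15%, range 0% to 45%.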

Compound 3, a percentage reported as inhibition, at one concentration (the size of the read-out at that concentration, not a potency): 0%
Compound 3: middle estimate off by 15 percentage points, on the high side; measured number inside the range.
By their numbers in this assay, from the lowest: compounds 2 and 3 (each within the scatter of the next); then compound 1.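

In this assay the step reads no change at the digits printed from compound 2 to compound 3 (within the scatter), so on this aromatic carbon, meta to a large group, diethylsulfamoyl, with no ring, gives the same number as 1,3-oxazol-5-yl. The other step reads a number 32 percentage points lower from compound 1 to compound 3 (beyond the scatter), so among these three compounds only the one with 1,3-thiazol-2-yl stands apart. Nothing available here explains this difference.

Open, going by these compounds, is whether a phenyl ring or an amine at this place would raise the read-out. Also open, on these data alone, is whether another sulfur-containing five-membered aromatic ring would behave like 1,3-thiazol-2-yl.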